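The source may report more compounds than this note shows. Statements on the series, on what has been measured and on what is new or still open speak of the compounds shown alone.

Compound 1 `COc1ccc(C2=CCN(S(=O)(=O)N3CCCC[C@@H]3C(=O)NO)CC2)cc1` gives 15000 nM in a functional assay on MONO-MAC-6 cells (Homo sapiens) for inhibition (a lower number here means a stronger inhibitor, a higher number a weaker inhibitor), while compound 2 `COc1cccc(C2=CCN(S(=O)(=O)N3CCCC[C@@H]3C(=O)NO)CC2)c1` gives 260 nM and compound 3 `O=C(NO)[C@H]1CCCCN1S(=O)(=O)N1CC=C(c2ccc(-c3ccccc3)cc2)CC1` gives 19000 nM. The change from compound 1 to compound 2 is 3-methoxyphenyl in place of 4-methoxyphenyl on a double-bonded ring carbon, and it brings a 58-fold lower number from compound 1 to compound 2 (1.76 log units; beyond the scatter). The change from compound 1 to compound 3 is phenyl in place of methoxy on an aromatic carbon, and it brings only a 1.3-fold higher number from compound 1 to compound 3 (0.10 log units; within the scatter).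

Compound 4 `O=C(NO)[C@H]1CCCCN1S(=O)(=O)N1CC=C(c2cccc(-c3ccccc3)c2)CC1` is not yet measured. It differs from compound 2 by phenyl in place of methoxy on an aromatic carbon. This is the same kind of change as that from compound 1 to compound 3, but the place differs: there the phenyl sits para to a large group, here meta to a large group. The cores of the two pairs differ by 3-methoxyphenyl in place of 4-methoxyphenyl on a double-bonded ring carbon. Resting on the small step from compound 1 to compound 3, the step from compound 2 to compound 4 in this assay is expected to be about a 1.5-fold higher number from compound 2 to compound 4 (0.19 log units; within the scatter). Compound 4 is therefore estimated at 400 nM, likely between 100 nM and 1800 nM.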

Compound 4, half-maximal inhibitory concentration: 7600 nM
Compound 4: middle estimate off by 19-fold (1.28 log units), on the low side, and the stated range ends below it.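

Swapping methoxy for phenyl does not carry from one core to the other in this assay, since on the core of compound 2 it brings a 29-fold higher number from compound 2 to compound 4 (1.47 log units; beyond the scatter), and the two steps clearly disagree: the same change on two cores in this assay, a 1.3-fold higher number (0.10 log units; within the scatter) from compound 1 to compound 3 and a 29-fold higher number (1.47 log units; beyond the scatter) from compound 2 to compound 4, 23-fold (1.36 log units) apart, beyond the scatter of two such steps. So a small step on one core gave no safe guide to the same change on the other, and the place of the group on the aromatic ring, meta to a large group in compound 4, cannot be ignored. Two pairs do not show why the cores differ, nor how this change would behave on any further core.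

Still open, on these data alone, is whether a group between methoxy and phenyl in size, such as ethoxy, would keep the low number of compound 2. The same question stands for a hydroxyl, an amine or a carboxylic acid in that place.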